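A few compounds are considered here, and "the series" means these few. Any claim that something is new, unique, unknown or untested is made for them only; others in the source may bear on it.

Working notes on the series

Compound 1 `CC1CCN(Cc2ccc3nc(NC(=O)N/N=C/c4cn(Cc5ccc(Cl)cc5Cl)c5ccccc45)sc3c2)CC1` carries a 2,4-dichlorophenyl group on a saturated chain carbon bound to an aromatic nitrogen; in a functional assay on A549 cells (Homo sapiens) for cytotoxicity, read by MTT assay, with a stated time of 72 h (on this read-out higher numbers stand for weaker inhibition and lower numbers for stronger inhibition), compound 1 gives 3640 nM. Compound 2 `Cc1ccc(Cn2cc(/C=N/NC(=O)Nc3nc4ccc(CN5CCC(C)CC5)cc4s3)c3ccccc32)cc1` carries a 4-methylphenyl group at the same position, and in this assay compound 2 gives 2180 nM. The single step in hand, a 1.7-fold lower number from compound 1 to compound 2 (0.22 log units; within the scatter), is a change at the phenyl ring of the benzyl group and lies within the scatter, so compound 2 and compound 1 stand together on the numbers shown and neither can be set above the other.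

Compound 3 `CC1CCN(Cc2ccc3nc(NC(=O)N/N=C/c4cn(Cc5ccc(C(C)(C)C)cc5)c5ccccc45)sc3c2)CC1` is the next member. It differs from compound 2 by tert-butyl in place of methyl on an aromatic carbon.

For the measured compounds named here, the only step that bears on this is the one from compound 1 to compound 2, which also exchanged the substitution on that same phenyl ring and gave a 1.7-fold lower number from compound 1 to compound 2 (0.22 log units; within the scatter). On that basis no step beyond the scatter is expected in this assay from compound 2 to compound 3, a 1.1-fold higher number from compound 2 to compound 3 (0.06 log units; within the scatter). Compound 3 is therefore estimated at 2500 nM, with a range of 900 nM to 7000 nM.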

Compound 3, half-maximal inhibitory concentration: 3710 nM
Estimate against measurement, compound 3: 1.5-fold (0.17 log units) below; low and high end bracket the measured number.
By their numbers in this assay, from the lowest: compounds 2, 1 and 3 (each within the scatter of the next).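

In this assay, tert-butyl in place of methyl on the aromatic carbon, with 4 heavy atoms entering where 1 leaves, gives a 1.7-fold higher number from compound 2 to compound 3 (0.23 log units; within the scatter), so this position carries the larger alkyl group without a step beyond the scatter. The exchange of 2,4-dichlorophenyl for 4-(tert-butyl)phenyl gives a 1.0-fold higher number from compound 1 to compound 3 (0.01 log units; within the scatter), so all three substituted phenyl groups on the saturated chain carbon stand together on these numbers and none can be set above another. Nothing measured alongside these values bears on this result.

The compounds shown leave open whether the phenyl ring responds at all to a group of another kind at this place, such as an amine or a carboxylic acid, as only methyl, tert-butyl and chlorine are represented on it. Also open, going by these compounds, is whether the same flat reading would hold with a longer chain in place of the benzyl group on the aromatic nitrogen.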